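The source may hold more compounds than are shown below. What is called first, only, known or untested is meant among the compounds shown, and "the series" means these compounds.

Among the measured compounds shown here, in a functional assay on L1210 cells (Mus musculus) for inhibition (on this read-out higher numbers stand for weaker inhibition and lower numbers for stronger inhibition), compound 2 (`COc1ccc(/C=C2\CCCc3ccccc3C2=O)cc1`) gives 340 nM and holds the lower of the two numbers so far, against compound 1 (`O=C1/C(=C/c2ccc(F)cc2)CCCc2ccccc21`) at 60300 nM on the same read-out. Next is compound 3 (`CN(C)c1ccc(/C=C2\CCCc3ccccc3C2=O)cc1`), which carries dimethylamino in place of methoxy on an aromatic carbon para to a large group. For the measured compounds named here, only one measured step bears on this change. That step a 180-fold lower number from compound 1 to compound 2 (2.25 log units; beyond the scatter) is large and beyond the scatter, yet it replaces fluoro rather than methoxy, so it is weak guidance and a repeat of its size is not expected. The data do not settle the direction, and the estimated change is a 1.4-fold lower number from compound 2 to compound 3 (0.13 log units; within the scatter) as a small move within the scatter. For compound 3 the expected value in this assay is 250 nM (estimated range 50 nM to 1500 nM).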

Compound 3, half-maximal inhibitory concentration: 1870 nM
Compound 3: the middle estimate sits 7.5-fold (0.87 log units) below what was measured; measured number above the stated range.
By their numbers in this assay, from the lowest: compound 2; then compound 3; then compound 1.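

In this assay, replacing methoxy with dimethylamino at this aromatic carbon, para to a large group, gives a 5.5-fold higher number from compound 2 to compound 3 (0.74 log units; beyond the scatter) and shows that the two groups are not interchangeable here, although each counts one hydrogen-bond acceptor and no donor. Dimethylamino in place of fluoro at the same carbon gives a 32-fold lower number from compound 1 to compound 3 (1.51 log units; beyond the scatter) and so keeps most of the gain seen with methoxy, which sets the three groups in the order methoxy, dimethylamino, fluoro, from the lowest number to the highest. Nothing at hand accounts for this order.

Still open, from the compounds shown here alone, is where ethoxy, hydroxy, chloro or a plain ring hydrogen at this carbon would fall relative to these three groups. The compounds shown also leave open whether the same order holds with any change to the shared core.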